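Anilinopyrimidine series: chloro for methyl at a fused ring

The source may report more compounds than this note shows. Statements on the series, on what has been measured and on what is new or still open speak of the compounds shown alone.

Measured compounds:
compound 1 `Cc1ccc2nc(Nc3nc(Nc4ccc(S(N)(=O)=O)cc4)ncc3C)sc2c1` — 2710 nM
compound 2 `CS(=O)(=O)c1ccc(Nc2ncc(F)c(Nc3nc4ccc(Cl)cc4s3)n2)cc1` — > 50000 nM
compound 3 `Cc1cnc(Nc2ccc(F)cc2)nc1Nc1nc2ccccc2s1` — > 50000 nM

Among the compounds with values here, in a functional assay on PC-3 cells (Homo sapiens) for antiproliferative activity, read by MTT assay, with a stated time of 48 h (on this read-out lower numbers stand for stronger inhibition and higher numbers for weaker inhibition), compound 1 gives 2710 nM, the only numerical value in the set. For compound 2 the read-out is a limit, > 50000 nM. For compound 3 the read-out is likewise a limit, > 50000 nM. Within the data shown here, compound 1 therefore stands alone as the one compound with a quantified result, the other two sitting at the limit of > 50000 nM in this assay, at which 2 of the 3 values shown sit.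

Compound 4 `Cc1cnc(Nc2ccc(S(N)(=O)=O)cc2)nc1Nc1nc2ccc(Cl)cc2s1` differs from compound 1 in one place: chloro in place of methyl on an aromatic carbon, meta to a fused ring and para to a fused ring. Among the measured compounds shown here, no measured pair in this assay makes the same change, so its effect cannot be read from the data. Compound 2 also carries a chloro group but differs from compound 1 in further places as well, and its limit gives no direction for this single exchange.

The expectation for compound 4 is a step of about a 1.1-fold higher number from compound 1 to compound 4 (0.04 log units; within the scatter) in this assay, within the usual scatter, with no clear direction. Compound 4 is estimated at 3000 nM, with a range from 800 nM to 15000 nM.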

Compound 4, half-maximal inhibitory concentration: 5400 nM
Estimate against measurement, compound 4: 1.8-fold (0.26 log units) below; the measured number falls inside the stated range.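

In this assay the exchange gives a 2.0-fold higher number from compound 1 to compound 4 (0.30 log units; within the scatter). Within the data shown here, this is the first single-place step, and it shows that chloro in place of methyl, at this position meta to a fused ring and para to a fused ring, leaves the read-out within the scatter. Nothing measured here accounts for the size of this step.

From the compounds shown here alone, whether this position accepts other groups, such as methoxy, an amine or a carboxylic acid, without moving the read-out beyond the scatter remains open. Also open is whether the same exchange gives a similar step when other parts of the core differ, as this is the only such pair shown.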